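Trifluoromethyl for Nitrile in a Glucosyltransferase Series

The compounds below may be only part of what the source reports. "The series", "measured", "known", "first", "only" and "open" are said of these compounds alone.

Compound 2 `N#Cc1ccc(-c2ccc(COCCCCCN3C[C@H](O)[C@@H](O)[C@H](O)[C@H]3CO)cc2)cc1` holds the higher of the two numbers measured: in an assay on isolated protein for inhibition of ceramide glucosyltransferase (Homo sapiens) (a higher number here means a weaker inhibitor, a lower number a stronger inhibitor), compound 2 gives 150 nM, while compound 1 `COc1ccccc1-c1ccc(COCCCCCN2C[C@H](O)[C@@H](O)[C@H](O)[C@H]2CO)cc1` gives 50 nM. Among the measured compounds shown here, the only step measured, a 3.0-fold higher number from compound 1 to compound 2 (0.48 log units; beyond the scatter), concerns a different exchange and bears on the new change only loosely. Compound 3 `OC[C@@H]1[C@@H](O)[C@H](O)[C@@H](O)CN1CCCCCOCc1ccc(-c2ccc(C(F)(F)F)cc2)cc1` carries trifluoromethyl in place of cyano on an aromatic carbon. For the measured compounds named here, with no direct precedent, a change of at most modest size, in either direction, is expected in this assay. Compound 3 is therefore estimated at 120 nM, within 40 nM to 360 nM, which means an expected step of a 1.3-fold lower number from compound 2 to compound 3 (0.10 log units; within the scatter).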

Compound 3, half-maximal inhibitory concentration: 20 nM
Estimate against measurement, compound 3: 6.0-fold (0.78 log units) above; the whole stated range lies above it.
By their numbers in this assay, from the lowest: compound 3; then compound 1; then compound 2.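

In this assay, the position answers more sharply to this exchange than the opening estimate allowed, with a 7.5-fold lower number from compound 2 to compound 3 (0.88 log units; beyond the scatter) and no change anywhere else in the molecule. The 4-(trifluoromethyl)phenyl group also outdoes the 2-methoxyphenyl group, with a 2.5-fold lower number from compound 1 to compound 3 (0.40 log units; beyond the scatter) placing compound 3 lowest of the three. Nothing shown here accounts for this difference.

From the compounds shown here alone, it remains open how a carboxylic acid or an amine would fare at this place on the aromatic ring. Going by these compounds, it is equally open whether the gain from trifluoromethyl would survive a longer chain on the shared core.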